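A few compounds are considered here, and "the series" means these few. Any claim that something is new, unique, unknown or untested is made for them only; others in the source may bear on it.

Measured so far in a functional assay on BXPC-3 cells (Homo sapiens) for cytotoxicity, read by fluorescence, with a stated time of 48 h; a lower number here means that less compound is needed, a higher number that more compound is needed for the effect:
compound 1 `CC(C)=CCC/C(C)=C/CC/C(C)=C/CSC[C@H](NC(=O)CCCCCN1CCN(C)CC1)C(=O)NC1CC1`, 6300 nM
compound 2 `CC(C)=CCC/C(C)=C/CC/C(C)=C/CSC[C@H](NC(=O)CCCCCN1CCCC1)C(=O)NC1CCCCC1`, 12700 nM
compound 3 `CC(C)=CCC/C(C)=C/CC/C(C)=C/CSC[C@H](NC(=O)CCCCCN1CCN(C)CC1)C(=O)NC1CCCC1`, a limit, > 20000 nM

Compound 2 gives the higher of the two numbers shown, but it sits within the scatter of compound 1. The reading for compound 3 is only (the limit of > 20000 nM in this assay, at which 1 of the 3 values shown sits), not a number.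

Compound 4 `CC(C)=CCC/C(C)=C/CC/C(C)=C/CSC[C@H](NC(=O)CCCCCN1CCCC1)C(=O)N1CCCC1` differs from compound 2 by pyrrolidin-1-yl in place of cyclohexylamino on a carbonyl carbon. Going by the values given here, no measured step matches this change. Among the compounds with values here, the only step touching the amide end, an at least 3.1-fold higher number from compound 1 to compound 3 (0.50 log units; beyond the scatter), went to weaker potency, so changes at this position are not neutral. A modest weakening is therefore expected for compound 4, a 1.3-fold higher number from compound 2 to compound 4 (0.10 log units; within the scatter), with a real chance that only a limit is reported. Compound 4 is estimated at 16000 nM, range 5000 nM to 40000 nM.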

Compound 4, half-maximal effective concentration: 6500 nM
The estimate for compound 4 lay 2.5-fold (0.39 log units) above the measured number; low and high end bracket the measured number.
By their numbers in this assay, from the lowest: compounds 1, 4 and 2 (each within the scatter of the next). At a limit, above all of these: compound 3.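

In this assay, pyrrolidin-1-yl in place of cyclohexylamino on a carbonyl carbon gives a 2.0-fold lower number from compound 2 to compound 4 (0.29 log units; within the scatter), so losing the amide hydrogen does not separate this pair. The amide end is therefore not uniformly sensitive: an at least 3.1-fold higher number from compound 1 to compound 3 (0.50 log units; beyond the scatter) lies beyond the scatter, while this change does not. Nothing measured here accounts for that difference.

Open, going by these compounds, is whether a dimethylamino or morpholin-4-yl group on the same carbonyl carbon would also stay within the scatter. Also open, on these data alone, is whether pyrrolidin-1-yl there would behave alike with the methylpiperazine chain end of compound 1.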